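This account rests on a few compounds, and the source may have more. Where it says the series, first, only, none or still open, it means among the compounds named here.

Series notes. In a functional assay on corpus cavernosum (Rattus norvegicus) for activation (on this read-out lower numbers stand for smaller maximal responses and higher numbers for larger maximal responses), compound 1 `O=c1[nH]c(-c2ccccc2O)nc2c1cnn2-c1ccccc1` gives 93%, compound 2 `CCCCOc1ccccc1-c1nc2c(cnn2-c2ccccc2)c(=O)[nH]1` gives 170%, and compound 3 `O=c1[nH]c(-c2ccccc2O)nc2c1cnn2-c1ccc(Br)cc1` gives 167%. Compound 3 thus stands second highest of the three numbers, within the scatter of compound 2 and far above compound 1, as the step of a number 74 percentage points higher from compound 1 to compound 3 (beyond the scatter) shows. Compound 4 `CCCCOc1ccccc1-c1nc2c(cnn2-c2ccc(Br)cc2)c(=O)[nH]1` is not yet measured in this assay; it differs from compound 3 by butyl in place of hydrogen on an oxygen on an aromatic ring. Within the data shown here, the one measured step of this kind is a number 77 percentage points higher from compound 1 to compound 2 (beyond the scatter), large and upward. That step began from the lowest value of the set, whereas compound 3 already sits high, so only a smaller rise is expected. For compound 4 the expected step is a number 23 percentage points higher from compound 3 to compound 4 (beyond the scatter). The estimate for compound 4 is 190%, with a range from 150% to 235%.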

Compound 4, largest response reached (Emax), in percent of the reference or control that the assay uses: 160%
Estimate against measurement, compound 4: 30 percentage points above; the measured number falls inside the stated range.
By their numbers in this assay, from the lowest: compound 1; then compounds 4, 3 and 2 (each within the scatter of the next).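

Once bromo is present, butyl on the oxygen brings no rise, and once butyl is present, bromo brings none: in this assay the steps are a number 7 percentage points lower from compound 3 to compound 4 (within the scatter) and a number 10 percentage points lower from compound 2 to compound 4 (within the scatter). The effect of the butyl change therefore depends on the group already present: the same change on two cores in this assay, a number 77 percentage points higher (beyond the scatter) from compound 1 to compound 2 and a number 7 percentage points lower (within the scatter) from compound 3 to compound 4, 84 percentage points apart, beyond the scatter of two such steps. The bromo change shows the same dependence: the same change on two cores in this assay, a number 74 percentage points higher (beyond the scatter) from compound 1 to compound 3 and a number 10 percentage points lower (within the scatter) from compound 2 to compound 4, 84 percentage points apart, beyond the scatter of two such steps.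

From the compounds shown here alone, whether a longer chain such as octyl on the oxygen, or chloro or an amine in place of bromo, would move the number away from this level stays open. Also open, going by these compounds, is whether the three high values mark an upper limit of the response.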